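Changing the group on the shared core and solubility

The compounds below may be only part of what the source reports. "The series", "measured", "known", "first", "only" and "open" are said of these compounds alone.

Measured compounds:
Compound 1, `O=C1CCCN1c1cnc(NCc2c(F)ccc3c2CCO3)n2cnnc12`: 640000 nM
Compound 2, `O=C(Nc1cnc(NCc2c(F)ccc3c2CCO3)n2cnnc12)c1cccnc1`: 12000 nM
Compound 3, `C[C@@H]1CC(=O)N(c2cnc(NCc3c(F)ccc4c3CCO4)n3cnnc23)C1`: 130000 nM

In a physicochemical assay for solubility, read by LC-MS, in phosphate buffer, with a stated time of 24 h, at pH 7.4 (on this read-out higher numbers stand for higher solubility and lower numbers for lower solubility), compound 3 stands second highest of the three numbers; its nearest neighbour is compound 1, reached by a 4.9-fold lower number from compound 1 to compound 3 (0.69 log units; beyond the scatter), and its furthest is compound 2, seen in an 11-fold higher number from compound 2 to compound 3 (1.03 log units; beyond the scatter). Compound 4, `CN(c1ccn(C)n1)c1cnc(NCc2c(F)ccc3c2CCO3)n2cnnc12`, has not yet been measured. It differs from compound 3 at a single place: methyl(1-methyl-1H-pyrazol-3-yl)amino in place of 4-methyl-2-oxopyrrolidin-1-yl on an aromatic carbon. Among the compounds with values here, the steps that bear on this are those that changed the group on the same aromatic carbon: a 53-fold lower number from compound 1 to compound 2 (1.73 log units; beyond the scatter) and an 11-fold higher number from compound 2 to compound 3 (1.03 log units; beyond the scatter), both large. A large step is therefore expected here too, while the smaller change a 4.9-fold lower number from compound 1 to compound 3 (0.69 log units; beyond the scatter) shows that even a methyl on the leaving group mattered. Since every replacement at this carbon so far moved the number well beyond the scatter, compound 4 is expected to give 40000 nM, within 8000 nM to 200000 nM, corresponding to an expected 3.3-fold lower number from compound 3 to compound 4 (0.51 log units; beyond the scatter).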

Compound 4, solubility: 130000 nM
For compound 4 the middle estimate is 3.3-fold (0.51 log units) below the measured one; measured number inside the range.
By their numbers in this assay, from the lowest: compound 2; then compounds 3 and 4 (each within the scatter of the next); then compound 1.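

In this assay, replacing 4-methyl-2-oxopyrrolidin-1-yl with methyl(1-methyl-1H-pyrazol-3-yl)amino gives no change at the digits printed from compound 3 to compound 4 (within the scatter), the only exchange of groups on this aromatic carbon among those shown that stays within the scatter. Two groups with different rings, one a five-membered non-aromatic ring and the other a five-membered aromatic ring, can therefore give matching numbers here. The same methyl(1-methyl-1H-pyrazol-3-yl)amino group still separates clearly from both other groups, with an 11-fold higher number from compound 2 to compound 4 (1.03 log units; beyond the scatter) and a 4.9-fold lower number from compound 1 to compound 4 (0.69 log units; beyond the scatter), so an aromatic ring in the group does not by itself bring a compound down to the number of compound 2.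

Nothing available here accounts for the match between compound 3 and compound 4. On these data alone, it also remains open whether a morpholin-4-yl group or a carboxylic acid on this carbon would give a number near compound 4 or near compound 2.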